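Boronic acid series: aryl swap on the branched thioether

The source may hold more compounds than are shown below. What is called first, only, known or untested is meant among the compounds shown, and "the series" means these compounds.

Measured so far in a functional assay on MCF7 cells (Homo sapiens) for antiproliferative activity, read by sulforhodamine B assay, with a stated time of 72 h; a higher number here means a weaker inhibitor, a lower number a stronger inhibitor:

compound 1 `CC(C)C[C@H](NC(=O)CSc1cc(NS(=O)(=O)c2cccs2)c2ccccc2c1O)B(O)O`: 9450 nM
compound 2 `CC(=O)Nc1ccc(S(=O)(=O)Nc2cc(SCC(=O)N[C@@H](CC(C)C)B(O)O)c(O)c3ccccc23)cc1`: 8660 nM
compound 3 `CC(C)C[C@H](NC(=O)C(C)Sc1cc(NS(=O)(=O)c2cccs2)c2ccccc2c1O)B(O)O`: 14700 nM

All three numbers sit close together. The change from compound 1 to compound 2 is 4-acetamidophenyl in place of thiophen-2-yl on a sulfonyl sulfur, and it gave a 1.1-fold lower number from compound 1 to compound 2 (0.04 log units; within the scatter). The cores of compound 3 and compound 1 differ by methyl in place of hydrogen on a saturated chain carbon bound to a carbonyl carbon and a sulfur, which gave a 1.6-fold higher number from compound 1 to compound 3 (0.19 log units; within the scatter).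

Compound 4 `CC(=O)Nc1ccc(S(=O)(=O)Nc2cc(SC(C)C(=O)N[C@@H](CC(C)C)B(O)O)c(O)c3ccccc23)cc1` is not yet measured. It differs from compound 3 by 4-acetamidophenyl in place of thiophen-2-yl on a sulfonyl sulfur. The place is described in the same words for both pairs, so this is the same change as from compound 1 to compound 2, now made on the core of compound 3. Among the compounds with values here, with only one earlier instance, the expectation rests on that single step: compound 4 is expected to show a 1.1-fold lower number from compound 3 to compound 4 (0.04 log units; within the scatter), close to a 1.1-fold lower number from compound 1 to compound 2 (0.04 log units; within the scatter), since the earlier instance of this change stayed within the scatter. The estimate for compound 4 in this assay is therefore 13500 nM, with a range from 7000 nM to 26000 nM.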

Compound 4, half-maximal inhibitory concentration: 8910 nM
Compound 4: middle estimate off by 1.5-fold (0.18 log units), on the high side; low and high end bracket the measured number.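

In this assay, 4-acetamidophenyl in place of thiophen-2-yl on the sulfonyl sulfur gave a 1.6-fold lower number from compound 3 to compound 4 (0.22 log units; within the scatter), and the two instances of this change agree: the same change on two cores in this assay, a 1.1-fold lower number (0.04 log units; within the scatter) from compound 1 to compound 2 and a 1.6-fold lower number (0.22 log units; within the scatter) from compound 3 to compound 4, 1.5-fold (0.18 log units) apart, within the scatter of two such steps. Methyl in place of hydrogen on the saturated chain carbon bound to a carbonyl carbon and a sulfur gave a 1.0-fold higher number from compound 2 to compound 4 (0.01 log units; within the scatter), and its two instances agree as well: the same change on two cores in this assay, a 1.6-fold higher number (0.19 log units; within the scatter) from compound 1 to compound 3 and a 1.0-fold higher number (0.01 log units; within the scatter) from compound 2 to compound 4, 1.5-fold (0.18 log units) apart, within the scatter of two such steps. Each change therefore carries from one core to the other only as a step within the scatter; this does not show that a step beyond the scatter would carry in the same way, and it says nothing beyond these four compounds and this one cell assay.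

The compounds shown leave open whether any change at these two places moves the number beyond the scatter, for instance an amine or a carboxylic acid in place of the acetamido group, or a longer chain in place of the methyl. They also leave open how the series would read with a carboxylic acid in place of the boronic acid.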